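Trimming one phenyl from a diphenylmethyl urea

The source may report more compounds than this note shows. Statements on the series, on what has been measured and on what is new or still open speak of the compounds shown alone.

Three compounds share a core and differ only in the group carried by the urea nitrogen. Compound 1 `Cc1nc(N)sc1CCCN/C(N)=N/C(=O)NC(c1ccccc1)C(C)C` gives 35.5 nM in an assay on membranes from Sf9 cells for displacement of a labelled ligand from histamine H2 receptor (Homo sapiens), read by scintillation counting, with a stated time of 60 min; on this read-out lower numbers stand for stronger inhibition and higher numbers for weaker inhibition; compound 2 `Cc1nc(N)sc1CCCN/C(N)=N/C(=O)NCc1ccco1` gives 10.5 nM in this assay; compound 3 `Cc1nc(N)sc1CCCN/C(N)=N/C(=O)NC(c1ccccc1)c1ccccc1` gives 43.7 nM in this assay. Compound 3 thus stands with the highest number of the three, close to compound 1 and furthest from compound 2.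

Compound 4 `Cc1nc(N)sc1CCCN/C(N)=N/C(=O)NCc1ccccc1` is made from compound 3 by the change (hydrogen in place of phenyl on a saturated chain carbon bound to an amide-type nitrogen and an aromatic carbon), which turns the diphenylmethyl group into a benzyl group. For the measured compounds named here, only one measured step bears on the same position: going from compound 1 to compound 3 gave a 1.2-fold higher number from compound 1 to compound 3 (0.09 log units; within the scatter), showing that swapping isopropyl for phenyl there hardly mattered. Removing a phenyl altogether is a larger change, and the smallest group in the set, the furanylmethyl of compound 2, goes with the lowest number seen. A modest drop in the number is therefore expected, and the step from compound 3 to compound 4 is estimated at a 2.2-fold lower number from compound 3 to compound 4 (0.34 log units; beyond the scatter). Compound 4 is expected to give about 20 nM in this assay, with a likely range from 8 nM to 50 nM.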

Compound 4, inhibition constant: 69.2 nM
The estimate for compound 4 lay 3.5-fold (0.54 log units) below the measured number; measured number outside the range, above it.
By their numbers in this assay, from the lowest: compound 2; then compounds 1, 3 and 4 (each within the scatter of the next).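

In this assay, taking the phenyl off the saturated chain carbon bound to an amide-type nitrogen and an aromatic carbon leaves the number within the scatter (a 1.6-fold higher number from compound 3 to compound 4 (0.20 log units; within the scatter)), and the same holds for taking off the isopropyl (a 1.9-fold higher number from compound 1 to compound 4 (0.29 log units; within the scatter)), so compounds 1, 3 and 4 do not separate whether that carbon carries phenyl, isopropyl or only hydrogen. For the compounds shown here, the one step here beyond the scatter comes from the ring instead: phenyl in place of furan-2-yl on a saturated chain carbon bound to an amide-type nitrogen (a 6.6-fold higher number from compound 2 to compound 4 (0.82 log units; beyond the scatter)), which shows that the low number of compound 2 does not simply come with having hydrogen on that carbon, as compound 4 has hydrogen there too. No other measurement is available to explain why furan-2-yl and phenyl differ.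

Going by these compounds, it remains open whether another ring in place of furan-2-yl, such as thiophen-2-yl or pyridin-2-yl, would read like compound 2 or like compound 4. Also open is how the furan-2-yl compound would respond to a phenyl or an isopropyl on its chain carbon, or how any of these compounds would respond to an amine or a carboxylic acid there.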